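The source may hold more compounds than are shown below. What is called first, only, known or untested is meant among the compounds shown, and "the series" means these compounds.

In a functional assay on MCF7 cells (Homo sapiens) for antiproliferative activity, read by MTT assay (on this read-out higher numbers stand for weaker inhibition and lower numbers for stronger inhibition), compound 1 `CC1(C)CCc2c(ccc(C(=O)/C=C/c3ccc(OCc4cn(-c5ccc(Cl)cc5)nn4)cc3)c2O)O1` is reported as "not active" (no number reported), with no number. Among the measured compounds shown here, compound 2 `Cc1c(-n2cc(COc3ccc(/C=C/C(=O)c4ccc5c(c4O)CCC(C)(C)O5)cc3)nn2)cccc1[N+](=O)[O-]` gives 145000 nM, the only number so far, so it cannot yet be ranked against a second value. Compound 3 `COc1ccc(-n2cc(COc3ccc(/C=C/C(=O)c4ccc5c(c4O)CCC(C)(C)O5)cc3)nn2)c([N+](=O)[O-])c1` remains unmeasured. It differs from compound 2 as follows: 4-methoxy-2-nitrophenyl in place of 2-methyl-3-nitrophenyl on an aromatic nitrogen. In short, 4-methoxy-2-nitrophenyl stands in place of 2-methyl-3-nitrophenyl on an aromatic nitrogen. For the measured compounds named here, no measured step is available to scale this change, so the step of a 1.2-fold lower number from compound 2 to compound 3 (0.08 log units; within the scatter) is expected to stay within the scatter, with no firm direction in this assay. For compound 3 the estimated value is 120000 nM, with an expected range of 40000 nM to 350000 nM.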

Compound 3, half-maximal inhibitory concentration: 73100 nM
For compound 3 the middle estimate is 1.6-fold (0.22 log units) above the measured one; measured number inside the range.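

In this assay, among the compounds shown here, 4-methoxy-2-nitrophenyl in place of 2-methyl-3-nitrophenyl on an aromatic nitrogen gives a 2.0-fold lower number from compound 2 to compound 3 (0.30 log units; within the scatter), the only measured step at this position, so the assay does not separate these two groups. Steps to compound 1 cannot be read, as it carries no number. No available evidence bears on this result.

Going by these compounds, it remains open whether a phenyl group bearing an amine or a carboxylic acid at this position would separate from compound 2 and compound 3 by more than the scatter. On these data alone, a longer chain between the aromatic nitrogen and the phenyl group is equally open.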